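The source may hold more compounds than are shown below. What is called first, only, known or untested is meant among the compounds shown, and "the series" means these compounds.

The compounds measured so far, in an ADME assay on HEK293 cells (Homo sapiens) for cytotoxicity, read by MTT assay, with a stated time of 48 h; a higher number here means a weaker inhibitor, a lower number a stronger inhibitor:
compound 1, `CCS(=O)(=O)Nc1ccc(NC(=O)c2ccc(C#N)cc2)cc1C`, > 250000 nM.
compound 2, `CCS(=O)(=O)Nc1ccc(NC(=O)c2cccc(C(F)(F)F)c2)cc1C`, 210000 nM.
compound 3, `Cc1cc(NC(=O)c2ccc(C#N)cc2)ccc1NS(=O)(=O)C(F)(F)F`, > 250000 nM.

For compound 1 the value is a limit of this assay, not a number. For compound 3 the value is likewise a limit. Compound 2 is the only one of the three with a number. Compound 3 differs from compound 1 by trifluoromethyl in place of ethyl on a sulfonyl sulfur. The step that the two limits leave unreadable from compound 1 to compound 3. Behind this stands (the limit of > 250000 nM in this assay, at which 2 of the 3 values shown sit).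

Compound 4, `Cc1cc(NC(=O)c2cccc(C(F)(F)F)c2)ccc1NS(=O)(=O)C(F)(F)F`, has not yet been measured. It differs from compound 2 by trifluoromethyl in place of ethyl on a sulfonyl sulfur, the same change as from compound 1 to compound 3, at a place described in the same words. How the core of compound 2 differs from the core of compound 1 is not broken down here. Because the measured step that the two limits leave unreadable from compound 1 to compound 3, the expectation rests mainly on the value of compound 2 in this assay, 210000 nM. The step expected is a 1.1-fold higher number from compound 2 to compound 4 (0.04 log units; within the scatter). For compound 4 the estimate is 230000 nM, expected to lie between 110000 nM and 250000 nM, with a fair chance that only a limit is reported.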

Compound 4, half-maximal inhibitory concentration: 131000 nM
The estimate for compound 4 lay 1.8-fold (0.24 log units) above the measured number, and the stated range covers the measured number.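

In this assay, putting trifluoromethyl in place of ethyl on the sulfonyl sulfur gives a 1.6-fold lower number from compound 2 to compound 4 (0.20 log units; within the scatter), so on this core the two compounds cannot be told apart. Among these compounds, the same change on the core of compound 1 cannot be read, because compound 1 and compound 3 both sit at a limit and not at a number: the limit of > 250000 nM in this assay, at which 2 of the 4 values shown sit. This leaves a single readable step, which shows no clear effect of the change on one core but cannot show that the change behaves alike on the other, since there is no second step to set beside it.

The compounds shown leave open what other groups on the sulfonyl sulfur would do, for example a longer chain such as butyl, or a carboxylic acid or an amine carried on that chain. They also leave open whether any such group would move the number in this assay by more than the scatter.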